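Moving the Chlorine Along the Benzyl Ring

A few compounds are considered here, and "the series" means these few. Any claim that something is new, unique, unknown or untested is made for them only; others in the source may bear on it.

Compound 1 `CC1=C(C(=O)Nc2ccc(Br)cc2)C(c2ccc(Cl)cc2Cl)N=C(SCc2ccccc2)N1` and compound 2 `CC1=C(C(=O)Nc2ccc(Br)cc2)C(c2ccc(Cl)cc2Cl)N=C(SCc2ccccc2Cl)N1` share one core and differ only in the ring that hangs from the sulfur. In a functional assay on the whole organism (artery, strain albino) with Rattus norvegicus as the target, with a stated time of 300 min, at a dose of 10 mg/kg by the oral route (on this read-out higher numbers stand for more inhibition at the one dose given (going by the name of the read-out) and lower numbers for less inhibition), compound 1 gives 22.1%, and compound 2 gives 36.4%. The step between them, a number 14.3 percentage points higher from compound 1 to compound 2 (beyond the scatter), is the only one measured so far, so compound 2 stands highest of the two numbers, with compound 1 as its nearest neighbour. Compound 3 `CC1=C(C(=O)Nc2ccc(Br)cc2)C(c2ccc(Cl)cc2Cl)N=C(SCc2cccc(Cl)c2)N1` keeps every atom of compound 2 and differs by 3-chlorophenyl in place of 2-chlorophenyl on a saturated chain carbon bound to a sulfur. Among the compounds with values here, the measured step from compound 1 to compound 2 shows what adding a chlorine does, not what moving it does, so no measured step bears directly on this change. The expected step is a number 3.4 percentage points lower from compound 2 to compound 3 (within the scatter), which stays within the usual scatter in either direction. Compound 3 is therefore expected to give 33% in this assay, with a range from 15% to 52%.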

Compound 3, a percentage reported as inhibition, in the whole organism at one dose (the size of the read-out at that dose, not a potency): 18.5%
Compound 3: middle estimate off by 14.5 percentage points, on the high side; the measured number falls inside the stated range.
By their numbers in this assay, from the lowest: compounds 3 and 1 (each within the scatter of the next); then compound 2.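

In this assay, the place of the chlorine on the benzyl ring counts, not just its presence: 3-chlorophenyl in place of 2-chlorophenyl gives a number 17.9 percentage points lower from compound 2 to compound 3 (beyond the scatter). Set against the ring without chlorine, the same compound shows a number 3.6 percentage points lower from compound 1 to compound 3 (within the scatter), so among these three compounds the earlier rise appears only with 2-chlorophenyl, and adding a chlorine to this ring does not raise the number wherever it sits. No measurement at hand explains why the two placements differ.

As far as these compounds go, it remains open whether the higher number belongs to chlorine itself or would also appear with a fluorine, a methyl or a methoxy group in its place. From the compounds shown here alone, the 4-chlorobenzyl group also remains open, so the three compounds give no full picture of chlorine placement on this ring.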